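Replacing a Biaryl Group in a Growth Hormone Secretagogue Agonist

The source may report more compounds than this note shows. Statements on the series, on what has been measured and on what is new or still open speak of the compounds shown alone.

Measured compounds:
compound 1 `CC(=O)c1ccc(N2C[C@@H](C)N[C@@H](C)C2)cc1NS(=O)(=O)c1ccc(-c2ccccn2)s1`, 39.8 nM
compound 2 `COc1ccc(F)c(-c2ccc(S(=O)(=O)Nc3cc(N4C[C@@H](C)N[C@@H](C)C4)ccc3OC)cc2)c1`, 0.398 nM

Of the compounds shown here, two have been tested in a functional assay for agonist activity at growth hormone secretagogue receptor type 1 (Homo sapiens), read by FLIPR; on this read-out lower numbers stand for an effect already at smaller amounts and higher numbers for an effect only at larger amounts of compound. Compound 1 `CC(=O)c1ccc(N2C[C@@H](C)N[C@@H](C)C2)cc1NS(=O)(=O)c1ccc(-c2ccccn2)s1` gives 39.8 nM in this assay. Compound 2 `COc1ccc(F)c(-c2ccc(S(=O)(=O)Nc3cc(N4C[C@@H](C)N[C@@H](C)C4)ccc3OC)cc2)c1` gives 0.398 nM in this assay, the lowest of the two numbers; its nearest neighbour is compound 1, whose number is higher by a gap that lies beyond the usual scatter. Going by the values given here, the two compounds differ in several places at once, so no single step between them can be read off.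

Compound 3 `COc1ccc(N2C[C@@H](C)N[C@@H](C)C2)cc1NS(=O)(=O)c1ccc(-c2ccc(C)o2)cc1` has not been measured. It differs from compound 2 in one place: 5-methylfuran-2-yl in place of 2-fluoro-5-methoxyphenyl on an aromatic carbon. Among the compounds with values here, compound 2 is the only direct reference for this change; the data contain no matching pair that would show how a change of this kind shifts the read-out. The expected outcome is a modest loss, so the step of a 5.0-fold higher number from compound 2 to compound 3 (0.70 log units; beyond the scatter) is estimated to run toward a higher number, possibly within the scatter. Compound 3 is estimated to give 2 nM in this assay, with a range from 0.4 nM to 10 nM.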

Compound 3, half-maximal effective concentration: 0.794 nM
Estimate against measurement, compound 3: 2.5-fold (0.40 log units) above; low and high end bracket the measured number.
By their numbers in this assay, from the lowest: compounds 2 and 3 (each within the scatter of the next); then compound 1.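

In this assay, going by these compounds alone, 5-methylfuran-2-yl in place of 2-fluoro-5-methoxyphenyl gives a 2.0-fold higher number from compound 2 to compound 3 (0.30 log units; within the scatter), the first single-place change that can be read, and it shows that this aromatic carbon, para to a large group, takes a different ring without a shift that can be told from the scatter. The change swaps a six-membered aromatic ring of carbon only for a five-membered aromatic ring with 1 hetero atom and goes from 9 heavy atoms to 6, so for this one pair neither the fluorine nor the methoxy group of compound 2 is needed to keep the number in this range. Nothing measured here bears on why the two groups read alike.

Both groups shown at this position are substituted aromatic rings, so it remains open whether the read-out would hold with a plain furan-2-yl, which would show what the methyl group of compound 3 contributes, or with an unsubstituted phenyl. From the compounds shown here alone, it is equally open how the position would respond to a group without an aromatic ring, such as a carboxylic acid, a primary amine or a longer alkyl chain.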